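This account rests on a few compounds, and the source may have more. Where it says the series, first, only, none or still open, it means among the compounds named here.

In an assay on HEK293 cells for binding affinity to Urotensin-2 receptor (Homo sapiens), read by radioligand binding (on this read-out higher numbers stand for weaker inhibition and lower numbers for stronger inhibition), compound 1 `CC(C)C[C@H](NC(=O)c1cc2ccccc2o1)C(=O)N[C@H]1CCN(Cc2ccc(OCCCN(C)C)cc2)C1` gives 158 nM, the lowest of the two numbers read in this series. Its epimer at the chain stereocentre, compound 3 `CC(C)C[C@@H](NC(=O)c1cc2ccccc2o1)C(=O)N[C@H]1CCN(Cc2ccc(OCCCN(C)C)cc2)C1`, gives 3160 nM, so that a 20-fold higher number from compound 1 to compound 3 (1.30 log units; beyond the scatter). For compound 2 `CC(C)C[C@H](NC(=O)c1cc2ccccc2o1)C(=O)N[C@@H]1CCN(Cc2ccc(OCCCN(C)C)cc2)C1` only a limit is recorded, < 10000 nM. That limit leaves a step that the limit leaves unreadable from compound 1 to compound 2 and a step that the limit leaves unreadable from compound 2 to compound 3 unreadable. Compound 4 `CC(C)C[C@H](NC(=O)c1cc2ccccc2[nH]1)C(=O)N[C@H]1CCN(Cc2ccc(OCCCN(C)C)cc2)C1` keeps both configurations of compound 1 and carries instead (1H-indol-2-yl in place of 1-benzofuran-2-yl on a carbonyl carbon). Among the compounds with values here, none of the measured steps changes this part of the structure; all three concern configuration alone, so they give no direct gauge of the exchange. The expected step is therefore modest, a 1.3-fold lower number from compound 1 to compound 4 (0.12 log units; within the scatter). Compound 4 is estimated at 120 nM, with a range from 30 nM to 500 nM.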

Compound 4, inhibition constant: 501 nM
For compound 4 the middle estimate is 4.2-fold (0.62 log units) below the measured one, outside the stated range (above it).
By their numbers in this assay, from the lowest: compound 1; then compound 4; then compound 3.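

In this assay, 1H-indol-2-yl in place of 1-benzofuran-2-yl on a carbonyl carbon gives a 3.2-fold higher number from compound 1 to compound 4 (0.50 log units; beyond the scatter), the only step shown that does not concern configuration. The number at this position therefore responds to an exchange of ring oxygen for ring nitrogen with both configurations held, although this step is smaller than a 20-fold higher number from compound 1 to compound 3 (1.30 log units; beyond the scatter). As far as these compounds go, it remains open whether 1-benzothiophen-2-yl on the same carbonyl carbon would stay close to compound 1 or move towards compound 4. Nothing shown gives a cause for the step from the benzofuran to the indole.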